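The source may report more compounds than this note shows. Statements on the series, on what has been measured and on what is new or still open speak of the compounds shown alone.

Measured so far in an ADME assay on the whole organism (strain Sprague-Dawley) for pharmacokinetics, with Rattus norvegicus as the target, using cassette dosing; a higher number here means faster removal of the compound, a lower number slower removal:
- Compound 1 `O=c1ccc(-c2cc(C[C@]3(O)CC[C@@H](Cc4ccc(Cl)cc4)CC3)no2)c[nH]1`: 16.8 mL/min/kg
- Compound 2 `O[C@]1(Cc2cc(-c3cn[nH]c3)on2)CC[C@H](Cc2ccc(Cl)cc2)CC1`: 11.7 mL/min/kg

Only these two compounds have a measured number, and they lie within the usual scatter of each other, so neither can be ranked above the other. Compound 3 `O[C@]1(Cc2cc(-c3cn[nH]c3)on2)CC[C@H](Cc2ccc(OC(F)(F)F)cc2)CC1` has not yet been measured. It keeps everything in compound 2 except one group: trifluoromethoxy in place of chloro on an aromatic carbon. The group sits on an aromatic carbon of a six-membered aromatic ring of carbon only, para to a large group.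

Going by the values given here, the one measured step, a 1.4-fold lower number from compound 1 to compound 2 (0.16 log units; within the scatter), changed a different part of the molecule. It stayed within the scatter, but a single step at another place says little about this new change. No measured pair shows what replacing chloro does here, so the data give no reason to expect a direction. The best starting point is compound 2 at 11.7 mL/min/kg, with no change expected beyond the scatter. The expected size is a 1.0-fold lower number from compound 2 to compound 3 (0.01 log units; within the scatter). For compound 3 the estimated clearance is 11.5 mL/min/kg, with an expected range from 5.5 mL/min/kg to 24 mL/min/kg.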

Compound 3, clearance: 6.2 mL/min/kg
Estimate against measurement, compound 3: 1.9-fold (0.27 log units) above, and the stated range covers the measured number.
By their numbers in this assay, from the lowest: compounds 3, 2 and 1 (each within the scatter of the next, the first and the last beyond it).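

In this assay, going by these compounds alone, the change at this place gives a 1.9-fold lower number from compound 2 to compound 3 (0.28 log units; within the scatter), and it is the first reading of any change on this ring, since the earlier step concerned a different part of the molecule. Trifluoromethoxy brings 1 hydrogen-bond acceptor where chloro had none, yet the step cannot be told apart from the repeat scatter of the measurement, so this single pair shows no firm direction for the change. No measurement of any other kind is available that could explain the number for compound 3.

The compounds shown leave open whether another group at this place, such as methoxy, a nitrile or a plain hydrogen, would move the number beyond the scatter of compound 2. They also leave open whether trifluoromethoxy would read the same on the core of compound 1, which carries a six-membered aromatic ring with 1 hetero atom where compound 2 and compound 3 carry a five-membered one with 2 hetero atoms.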